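A few compounds are considered here, and "the series" means these few. Any claim that something is new, unique, unknown or untested is made for them only; others in the source may bear on it.

Among the compounds with values here, in a functional assay on A549 cells (Homo sapiens) for antiproliferative activity, read by MTT assay (on this read-out higher numbers stand for weaker inhibition and lower numbers for stronger inhibition), compound 1 `Cc1c(-n2cc(COc3ccc(/C=C/C(=O)c4cc5c(cc4O)OC(C)(C)CC5)cc3)nn2)cccc1[N+](=O)[O-]` gives 65900 nM and compound 2 `Cc1ccc(-n2cc(COc3ccc(/C=C/C(=O)c4cc5c(cc4O)OC(C)(C)CC5)cc3)nn2)cc1Br` gives 125000 nM, so compound 2 stands level with the only other measured compound. Within the data shown here, the one measured step, a 1.9-fold higher number from compound 1 to compound 2 (0.28 log units; within the scatter), merely exchanges one ring-bearing group for another. Compound 3 `CCCCCCCCn1cc(COc2ccc(/C=C/C(=O)c3cc4c(cc3O)OC(C)(C)CC4)cc2)nn1` has octyl in place of 3-bromo-4-methylphenyl on an aromatic nitrogen. Among the measured compounds shown here, no measured compound carries such a chain, so the evidence is thin, and no step beyond the scatter is expected in this assay. The expected change is a 1.6-fold lower number from compound 2 to compound 3 (0.19 log units; within the scatter). For compound 3 the estimate is 80000 nM, with an expected range of 20000 nM to 250000 nM.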

Compound 3, half-maximal inhibitory concentration: 50800 nM
Compound 3: the middle estimate sits 1.6-fold (0.20 log units) above what was measured, within the range that was stated.
By their numbers in this assay, from the lowest: compounds 3, 1 and 2 (each within the scatter of the next, the first and the last beyond it).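

With octyl on the aromatic nitrogen, a group with no ring, this assay shows a 2.5-fold lower number from compound 2 to compound 3 (0.39 log units; beyond the scatter), a modest change, and a 1.3-fold lower number from compound 1 to compound 3 (0.11 log units; within the scatter). A ring at this position is therefore not required for activity at this level, at least among these three compounds. Nothing measured here accounts for the step from the ring-bearing group to the chain. Still open, as far as these compounds go, is whether a shorter chain such as butyl, or an octyl chain ending in an amine or a carboxylic acid, would shift the number further.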